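This account rests on a few compounds, and the source may have more. Where it says the series, first, only, none or still open, it means among the compounds named here.

Compound 2 `O=C1NC(=S)/C(=C/c2ccccc2Cl)S1` and compound 1 `O=C1NC(=S)/C(=C/c2ccccc2Br)S1` share one core and differ only in the halogen on the aromatic ring. In a functional assay on NCI-H292 cells (Homo sapiens) for cytotoxicity, read by MTT assay, with a stated time of 72 h, tested at 2.5 ug/mL (a lower number here means less inhibition of growth, a higher number more inhibition of growth at the concentration tested), compound 1 gives 16.2%, and in the same test compound 2 gives 19.9%. Among the compounds with values here, the only measured step between them, a number 3.7 percentage points higher from compound 1 to compound 2 (within the scatter), stays inside the scatter, so the two numbers cannot be ordered. Among the two measured compounds, compound 2 therefore carries the higher of the two figures, though the gap to compound 1 is not one the assay can resolve.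

Compound 3 `O=C1NC(=S)/C(=C/c2ccccc2F)S1` is the next member of the series and has not been measured. It differs from compound 2 by fluoro in place of chloro on an aromatic carbon. Within the data shown here, the one step that bears on this change is the halogen swap from compound 1 to compound 2, which was small and within the scatter. On that basis no step beyond the scatter is expected in this assay for compound 3, and its estimated shift a number 1.9 percentage points lower from compound 2 to compound 3 (within the scatter) is accordingly close to zero. Compound 3 is thus expected to give about 18%, with a likely range from 5% to 32%.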

Compound 3, percent growth inhibition at one concentration: 7.78%
Estimate against measurement, compound 3: 10.2 percentage points above; the range from low to high includes it.
By their numbers in this assay, from the lowest: compounds 3, 1 and 2 (each within the scatter of the next, the first and the last beyond it).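

In this assay, within the data shown here, the exchange of fluoro in place of chloro on an aromatic carbon gives a number 12.1 percentage points lower from compound 2 to compound 3 (beyond the scatter) and is the one change at this position that the assay resolves, which the earlier bromo and chloro pair could not show. The other halogen exchange, fluoro in place of bromo, gives a number 8.4 percentage points lower from compound 1 to compound 3 (within the scatter) and remains unresolved, so compound 1 cannot be separated from either compound 2 or compound 3, and only the two ends of the short series stand apart. The identity of the halogen at this position can therefore change the reading, but the three compounds support no graded trend across the halogens, and nothing available explains the step.

The compounds shown leave open how this position would respond to a group other than a halogen, such as a methoxy group, an amine or a carboxylic acid, or to plain hydrogen. They also leave open whether the gap between compound 2 and compound 3 would persist at other concentrations, since each reading comes from a single concentration.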